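The compounds below may be only part of what the source reports. "The series", "measured", "known", "first", "only" and "open" are said of these compounds alone.

Compound 3, `COC(=O)c1ccc(C2SCC(=O)N2c2ccc(N3CCN(S(=O)(=O)c4ccccc4)CC3)cn2)c(OC)c1`, is the reference point here. In a functional assay on K562 cells (Homo sapiens) for antiproliferative activity, read by MTT assay and trypan blue exclusion, with a stated time of 72 h (a lower number here means a stronger inhibitor, a higher number a weaker inhibitor), compound 3 gives 65600 nM, the lowest of the two numbers measured, though the nearest value, that of compound 1, `COC(=O)c1ccc(C2SCC(=O)N2c2ccc(N3CCN(Cc4cccc([N+](=O)[O-])c4)CC3)cn2)c(OC)c1`, sits within the scatter: compound 1 gives 68700 nM. Compound 2, `COC(=O)c1ccc(C2SCC(=O)N2c2ccc(N3CCN(S(=O)(=O)c4ccc(F)cc4)CC3)cn2)c(OC)c1`, gives only a limit in this assay, > 100000 nM. The steps measured so far are all small: a 1.0-fold lower number from compound 1 to compound 3 (0.02 log units; within the scatter), an at least 1.4-fold higher number from compound 1 to compound 2 (0.16 log units; that floor lies within the scatter), and an at least 1.5-fold lower number from compound 2 to compound 3 (0.18 log units; that floor lies within the scatter), the last two resting on (the limit of > 100000 nM in this assay, at which 1 of the 3 values shown sits).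

Compound 4, `COC(=O)c1ccc(C2SCC(=O)N2c2ccc(N3CCN(S(=O)(=O)c4cc(Cl)ccc4Cl)CC3)cn2)c(OC)c1`, differs from compound 3 only on the sulfonyl group: 2,5-dichlorophenyl in place of phenyl on a sulfonyl sulfur. Going by the values given here, the one step that bears on this, from compound 2 to compound 3, changed a single halogen on that ring and stayed within the scatter, so no step beyond the scatter is expected here either. Compound 4 is therefore estimated at 70000 nM, between 30000 nM and 160000 nM, which would mean a step of a 1.1-fold higher number from compound 3 to compound 4 (0.03 log units; within the scatter).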

Compound 4, half-maximal inhibitory concentration: > 100000 nM
Compound 4: a limit, no number; the forecaster's own chance of this, stated with the estimate: 35%; middle value at least 1.4-fold (0.15 log units) away from the limit.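

In this assay compound 4 gives > 100000 nM, which is a limit of the assay and not a number. Placing 2,5-dichlorophenyl on the sulfonyl sulfur gives an at least 1.5-fold higher number from compound 3 to compound 4 (0.18 log units; that floor lies within the scatter), and the change from the 3-nitrobenzyl group gives an at least 1.4-fold higher number from compound 1 to compound 4 (0.16 log units; that floor lies within the scatter), so neither floor shows a step beyond the scatter. What is new is that a second halogen-bearing ring on the sulfonyl sulfur, after the 4-fluorophenyl of compound 2, ends at the limit while the phenyl of compound 3 has a number, and the step between compound 2 and compound 4 cannot be read: the limit of > 100000 nM in this assay, at which 2 of the 4 values shown sit.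

The compounds shown leave open what numbers lie behind the limits of compound 2 and compound 4. Also open, from the compounds shown here alone, is whether a methoxy or an amine on the phenyl ring of compound 3 would give a step beyond the scatter.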